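This account rests on a few compounds, and the source may have more. Where it says the series, first, only, none or still open, it means among the compounds named here.

In a functional assay on CHO cells for antagonist activity at transient receptor potential cation channel subfamily V member 1 (Rattus norvegicus) (a lower number here means a stronger inhibitor, a higher number a weaker inhibitor), three compounds built on a shared core have been measured. Compound 1, `CC(NC(=O)/C=C/c1ccc(C(C)(C)C)cc1)c1ccc(NS(C)(=O)=O)c(F)c1`, gives 23.9 nM. Compound 2, `CC(C(=O)NCc1ccc(Cl)cc1)c1ccc(NS(C)(=O)=O)c(F)c1`, gives 367 nM, and compound 3, `CC(C(=O)NCc1ccc(C(F)(F)F)cc1)c1ccc(NS(C)(=O)=O)c(F)c1`, gives 274 nM. Among these three numbers compound 3 stands second highest: its nearest neighbour is compound 2, whose number is within the scatter of its own, while compound 1 lies far lower and that gap is beyond the scatter.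

Compound 4, `CC(C(=O)NCc1ccc(C2CC2)cc1)c1ccc(NS(C)(=O)=O)c(F)c1`, has not yet been measured in this assay. It differs from compound 3 in one place: cyclopropyl in place of trifluoromethyl on an aromatic carbon. For the measured compounds named here, the only measured step that bears on this kind of change, an exchange of the group on that same aromatic carbon, is a 1.3-fold lower number from compound 2 to compound 3 (0.13 log units; within the scatter), a step that stays within the scatter. With nothing else to go on, a change of one small group for another at that spot is expected to leave the number roughly where compound 3 already is, so no step beyond the scatter is anticipated in this assay.

Compound 4 is therefore estimated to give 260 nM, most likely between 110 nM and 650 nM, which corresponds to an expected step of a 1.1-fold lower number from compound 3 to compound 4 (0.02 log units; within the scatter).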

Compound 4, inhibition constant: 55.5 nM
Estimate against measurement, compound 4: 4.7-fold (0.67 log units) above, and the stated range ends above it.
By their numbers in this assay, from the lowest: compound 1; then compound 4; then compounds 3 and 2 (each within the scatter of the next).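

In this assay, the group on this aromatic carbon, para to a large group, turns out to matter: cyclopropyl in place of trifluoromethyl gives a 4.9-fold lower number from compound 3 to compound 4 (0.69 log units; beyond the scatter), and cyclopropyl in place of chloro gives a 6.6-fold lower number from compound 2 to compound 4 (0.82 log units; beyond the scatter). Both steps lie beyond the usual scatter, whereas the exchange of chloro for trifluoromethyl, a 1.3-fold lower number from compound 2 to compound 3 (0.13 log units; within the scatter), stayed within it, so the earlier pair had made this spot look indifferent to the group it carries, and among these three groups only cyclopropyl, the one with a ring, stands apart. Nothing measured here says what lies behind this drop.

The compounds shown leave open whether the lower number belongs to the three-membered ring itself or would also appear with other carbon groups on that aromatic carbon, such as isopropyl or cyclobutyl. For the compounds shown here, they also leave open how a group of a different kind, such as an amine or a methoxy group, would behave there, since the picture at this position rests on only three groups.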